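Acetamido for methyl: a cytotoxicity check at one dose

The source may report more compounds than this note shows. Statements on the series, on what has been measured and on what is new or still open speak of the compounds shown alone.

Measured compounds:
Compound 1 `O=C(Nc1cccc(N2CCCC2=O)c1)C1CCCN(C(=O)c2cc(C(F)(F)F)cc(C(F)(F)F)c2)C1`: 0%
Compound 2 `Cc1cccc(C(=O)N2CCCC(C(=O)Nc3ccc(Cl)cc3)C2)c1`: 0%
Compound 3 `CSc1cccc(NC(=O)C2CCCN(C(=O)c3cc(C(F)(F)F)cc(C(F)(F)F)c3)C2)c1`: 0%

All three share a core in which a piperidine amide carries an aromatic ring on each side. In an ADME assay on PC-3 cells (Homo sapiens) for cytotoxicity, read by WST assay, tested at 100 uM (a lower number here means less inhibition, a higher number more inhibition at the concentration tested (going by the name of the read-out)), compound 1 gives 0%. Compound 3 differs from it only in that a methylsulfanyl replaces the 2-oxopyrrolidin-1-yl group, and no change at the digits printed from compound 1 to compound 3 (within the scatter). Compound 2 gives 0%, which sits at the same level as the values of compound 1 and compound 3.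

The unmeasured compound 4 `CC(=O)Nc1cccc(C(=O)N2CCCC(C(=O)Nc3ccc(Cl)cc3)C2)c1` is derived from compound 2 by a single change: acetamido in place of methyl on an aromatic carbon. Among the measured compounds shown here, no measured pair exchanges an acetamido for a methyl, so no step bears directly on this change. For the measured compounds named here, the only step available, from compound 1 to compound 3, stayed within the scatter, and every measured compound shows no inhibition at this concentration. The expected step in this assay is therefore none beyond the scatter, no change at the digits printed from compound 2 to compound 4 (within the scatter).

Compound 4 is estimated at 0%, within a range of 0% to 10%.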

Compound 4, a percentage reported as inhibition, at one concentration (the size of the read-out at that concentration, not a potency): 4%
Compound 4: the middle estimate sits 4 percentage points below what was measured, and the stated range covers the measured number.
By their numbers in this assay, from the lowest: compounds 1, 2, 3 and 4 (each within the scatter of the next).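

Among the compounds shown here, this is the first measured exchange at this aromatic carbon, meta to a large group: methyl, a single carbon, gives way to acetamido, with its four heavy atoms, one hydrogen-bond donor and one hydrogen-bond acceptor, and in this assay the result is a number 4 percentage points higher from compound 2 to compound 4 (within the scatter). Within this single pair, then, adding those atoms at this place keeps the read-out inside the usual scatter at the one concentration tested, something the earlier step could not show, as it exchanged a different pair of groups on a different compound. Nothing measured here offers an explanation for this result, and one pair on its own cannot supply one.

The compounds shown leave open whether other groups at this position, such as an amine, a carboxylic acid or a longer chain, would also stay within the scatter of compound 2 in this assay. They also leave open whether acetamido would read the same on the other side of the series, for instance in place of the methylsulfanyl of compound 3.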